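Moving the chlorine on the aryl-tetrazole ketone series

The compounds below may be only part of what the source reports. "The series", "measured", "known", "first", "only" and "open" are said of these compounds alone.

Two compounds of this set have numbers in an assay on microsomes from brain for inhibition of Fatty-acid amide hydrolase 1 (Rattus norvegicus), read by fluorescence and HPLC, with a stated time of 60 min; on this read-out higher numbers stand for weaker inhibition and lower numbers for stronger inhibition. Compound 1 `CCCCCCCCc1ccc(OCC(=O)Cn2nnc(SC)n2)cc1` gives 31 nM. Compound 2 `CCCCCCCCc1ccc(OCC(=O)Cn2nnc(-c3cccc(Cl)c3)n2)cc1` gives 24 nM, and so it has the lowest of the two numbers, with compound 1 nearest to it. Within the data shown here, the step of a 1.3-fold lower number from compound 1 to compound 2 (0.11 log units; within the scatter) is the only measured step that touches the group on the five-membered ring.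

Compound 3 `CCCCCCCCc1ccc(OCC(=O)Cn2nnc(-c3ccccc3Cl)n2)cc1` has not yet been measured in this assay. It differs from compound 2 by 2-chlorophenyl in place of 3-chlorophenyl on an aromatic carbon, the two having the same atoms joined differently. Among the measured compounds shown here, no measured step in this assay moves a substituent from one position of a phenyl to another, so the only guide is that the exchange of the whole group on this carbon, a 1.3-fold lower number from compound 1 to compound 2 (0.11 log units; within the scatter), stayed within the scatter. On that basis no step beyond the scatter is expected in this assay for compound 3, and the estimated step of a 1.5-fold higher number from compound 2 to compound 3 (0.16 log units; within the scatter) is small. Compound 3 is therefore expected to give about 35 nM, with a range from 10 nM to 120 nM.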

Compound 3, half-maximal inhibitory concentration: 32 nM
The estimate for compound 3 lay 1.1-fold (0.04 log units) above the measured number, within the range that was stated.
By their numbers in this assay, from the lowest: compounds 2, 1 and 3 (each within the scatter of the next).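

In this assay, among these compounds, moving the chlorine gives a 1.3-fold higher number from compound 2 to compound 3 (0.12 log units; within the scatter), the first measured step in which a substituent changes position on the phenyl, and it stays within the scatter. The exchange of methylsulfanyl for 2-chlorophenyl gives a 1.0-fold higher number from compound 1 to compound 3 (0.01 log units; within the scatter), so on this aromatic carbon of the five-membered ring, both chlorophenyl groups shown remain within the scatter of methylsulfanyl, and the three compounds cannot be separated by this read-out. Nothing available explains why these exchanges leave the number within the scatter.

It remains open whether this tolerance extends to a plain phenyl, or to a phenyl bearing a carboxylic acid or an amine, on the same carbon, since a group that departs further from those shown might produce a step beyond the scatter. All three compounds also share the rest of the core of compound 1, so they leave open whether an exchange elsewhere in the molecule, such as a shorter chain on the other phenyl or an alcohol in place of the carbonyl, would move the number by more than the scatter.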